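Taking an acetoxy group off compound 2

The source may hold more compounds than are shown below. What is called first, only, known or untested is meant among the compounds shown, and "the series" means these compounds.

In a functional assay on cells (HCT cell line, Homo sapiens) for cytotoxicity (a higher number here means that more compound is needed for the effect, a lower number that less compound is needed), compound 2 (`CCCCC/C=C\C[C@@]1(O)C=C(Cl)C(=O)[C@@H]1[C@@H](OC(C)=O)[C@H](OC(C)=O)[C@H](CCCC(=O)OC)OC(C)=O`) gives 40 nM. Compound 3 (`CCCCC/C=C\C[C@@]1(O)C=C(Cl)C(=O)/C1=C\[C@H](C(C)=O)[C@H](CCCC(=O)OC)OC(C)=O`) gives 27 nM, and these two values lie within the usual scatter of each other. Compound 1 (`CC/C=C/C/C=C\C[C@@]1(O)C=C(Cl)C(=O)/C1=C/[C@H](OC(C)=O)[C@H](CCCC(=O)OC)OC(C)=O`) gives 370 nM, so it needs clearly more compound than compound 2, by a gap beyond the scatter.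

The next compound, compound 4 (`CCCCC/C=C\C[C@@]1(O)C=C(Cl)C(=O)[C@@H]1C[C@H](OC(C)=O)[C@H](CCCC(=O)OC)OC(C)=O`), is compound 2 with hydrogen in place of acetoxy on a saturated chain carbon bound to a saturated chain carbon and a saturated ring carbon.

Among the compounds with values here, no measured pair differs in one place only, so the evidence for this change is indirect. Set against compound 2, compound 3 has a side chain built differently and still gives 27 nM. Compound 1 goes against this reading, since its side chain also differs and it gives 370 nM, although its other chain differs too. On balance, a small change is more likely than a large one. The expected step of a 1.3-fold higher number from compound 2 to compound 4 (0.10 log units; within the scatter) stays within the scatter, with no firm direction. In this assay, the estimate for compound 4 is 50 nM, with an expected range of 15 nM to 170 nM.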

Compound 4, half-maximal effective concentration: 360 nM
The estimate for compound 4 lay 7.2-fold (0.86 log units) below the measured number, and the stated range ends below it.
By their numbers in this assay, from the lowest: compounds 3 and 2 (each within the scatter of the next); then compounds 4 and 1 (each within the scatter of the next).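

Replacing this one acetoxy group with hydrogen, on a saturated chain carbon bound to a saturated chain carbon and a saturated ring carbon, gives a 9.0-fold higher number from compound 2 to compound 4 (0.95 log units; beyond the scatter) in this assay. The earlier compounds shown here differed from one another in more than one place, so they could not isolate this group; compounds 2 and 4 differ here alone, which ties the whole step to this single exchange and shows that this position is not indifferent to the change. Nothing available explains why the number moves this way.

The compounds shown compare only acetoxy and hydrogen at this carbon, so it remains open how a methoxy group, an amine or a longer ester would behave there. Within the data shown here, it is also open whether the same exchange would produce a step of this size on a differently built side chain, such as the one in compound 1.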